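Exchanging Benzyl for Cyclopropyl on the Amine Nitrogen

The compounds below may be only part of what the source reports. "The series", "measured", "known", "first", "only" and "open" are said of these compounds alone.

Compound 1 `COc1cc(Oc2cccc(Nc3ccccc3)c2)cc(OC)c1CNCc1ccccc1` is examined in a functional assay on HCT-116 cells (Homo sapiens) for inhibition, read by MTT assay, with a stated time of 72 h (a lower number here means a stronger inhibitor, a higher number a weaker inhibitor), where compound 1 gives 4070 nM. Among the compounds with values here, only one other number has been recorded, and it stands within the scatter of this one: its neighbour compound 2 `COc1cc(Oc2cccc(Nc3ccccc3)c2)cc(OC)c1CNCc1ccc(F)cc1`, in this assay, gives 4220 nM, and the single measured step, a 1.0-fold higher number from compound 1 to compound 2 (0.02 log units; within the scatter), is too small to read as a change. The unmeasured compound 3 `COc1cc(Oc2cccc(Nc3ccccc3)c2)cc(OC)c1CNC1CC1` differs from compound 1 at another place: cyclopropyl in place of benzyl on an amine nitrogen. Within the data shown here, no measured step touches the group on the amine nitrogen; the step from compound 1 to compound 2 alters the benzyl ring but keeps the benzyl itself, so it shows only that a small alteration there leaves the number where it was. With nothing to anchor the exchange of benzyl for cyclopropyl, the expectation for compound 3 rests on compound 1 alone and carries a wide range. Compound 3 is expected to give about 5000 nM in this assay, with a likely range from 1500 nM to 16000 nM. The step this estimate means, a 1.2-fold higher number from compound 1 to compound 3 (0.09 log units; within the scatter), is expected to be small and uncertain in direction.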

Compound 3, half-maximal inhibitory concentration: > 20000 nM
Compound 3 ended at the assay's limit; the forecaster's own chance of this, stated with the estimate: 5%; middle value at least 4.0-fold (0.60 log units) from the limit.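

Compound 3 stands at a limit of the assay, not at a number: the limit of > 20000 nM in this assay, at which 1 of the 3 values shown sits.

Even read as a limit, the exchange on the amine nitrogen counts for more than anything the earlier pair could show: in this assay it gives an at least 4.9-fold higher number from compound 1 to compound 3 (0.69 log units; beyond the scatter), and starting from the fluorinated neighbour it gives an at least 4.7-fold higher number from compound 2 to compound 3 (0.67 log units; beyond the scatter). The alteration of the benzyl ring had left the number in place (a 1.0-fold higher number from compound 1 to compound 2 (0.02 log units; within the scatter)), so this position looked indifferent, whereas replacing the whole benzyl with cyclopropyl makes compound 3 a weaker inhibitor than either compound 1 or compound 2.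

The compounds shown leave open whether the loss follows the absence of the aromatic ring or simply the smaller carbon count of the group, and how far compound 3 actually lies past its limit also remains unknown. A cyclohexyl ring, a phenethyl chain or a plain methyl on the same nitrogen would help to separate these readings.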